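Trimethoxyphenyl to dimethoxyphenyl in an acrylic acid series

A few compounds are considered here, and "the series" means these few. Any claim that something is new, unique, unknown or untested is made for them only; others in the source may bear on it.

Measured so far:
compound 1, `COc1ccc(/C(=C\c2c[nH]c3ccc(OCc4ccccc4)cc23)C(=O)O)cc1`, 58400 nM
compound 2, `COc1cc(/C(=C\c2cn(C(C)=O)c3ccc(OCc4ccccc4)cc23)C(=O)O)cc(OC)c1OC`, 57100 nM
compound 3, `COc1ccc(Cn2cc(/C=C(/C(=O)O)c3ccccc3)c3cc(OCc4ccccc4)ccc32)cc1`, 64500 nM

All three numbers come from a functional assay on M14 cells (Homo sapiens) for cytotoxicity, read by MTT assay, with a stated time of 72 h; on this read-out higher numbers stand for weaker inhibition and lower numbers for stronger inhibition. Compound 2 holds the lowest of the three numbers, but its neighbours sit close: compound 1 gives 58400 nM, a gap within the scatter, and compound 3 gives 64500 nM, also within the scatter. The three compounds therefore cannot be ordered on these numbers; they read as one cluster despite their different aryl substitution and different substitution on the indole nitrogen of the shared core.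

Compound 4, `COc1ccc(/C(=C\c2cn(C(C)=O)c3ccc(OCc4ccccc4)cc23)C(=O)O)cc1OC`, has not been measured. It differs from compound 2 by hydrogen in place of methoxy on an aromatic carbon; cut one bond further out, the change reads 3,4,5-trimethoxyphenyl to 3,4-dimethoxyphenyl.

Going by the values given here, no step between measured compounds is available for this kind of change. Since compounds 1, 2 and 3 all fall within the scatter of one another in this assay, no step beyond the scatter is expected from removing one methoxy group. Compound 4 is expected to land near compound 2, at an estimated 60000 nM, with a range of 25000 nM to 140000 nM, so that the estimated step of a 1.1-fold higher number from compound 2 to compound 4 (0.02 log units; within the scatter) is expected to stay within the scatter.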

Compound 4, half-maximal inhibitory concentration: 65500 nM
Beside the measured number, compound 4's estimate is 1.1-fold (0.04 log units) below it, and the stated range covers the measured number.
By their numbers in this assay, from the lowest: compounds 2, 1, 3 and 4 (each within the scatter of the next).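

Going by these compounds alone, the first step that changes one place only, hydrogen in place of methoxy on an aromatic carbon, reads in this assay as a 1.1-fold higher number from compound 2 to compound 4 (0.06 log units; within the scatter). At this position, ortho to a methoxy group and meta to a large group, the 3,4,5-trimethoxyphenyl group can therefore become 3,4-dimethoxyphenyl with no shift beyond the scatter, which compounds 1 and 3 could not show, as neither differs from compound 2 in one place only. No separate measurement bears on this result.

Going by these compounds, whether this position stays as undemanding with other groups, such as an amine, a hydroxyl or a longer alkoxy chain, remains open, as does the outcome of taking away a further methoxy group from the same ring. All four compounds also fall within one cluster in this assay, so the compounds shown do not yet reveal whether any change on this ring can move the number beyond the scatter.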